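Methoxy to Chloro on the Outer Phenyl Group

The compounds below may be only part of what the source reports. "The series", "measured", "known", "first", "only" and "open" are said of these compounds alone.

Three compounds share one core. Compound 1 `O=C(CN1CCN(c2ccccc2)CC1)N1CCN(c2nnc(-c3ccc(Cl)cc3)c(-c3ccc(Cl)cc3)n2)CC1` carries an unsubstituted phenyl group, and in a functional assay on MCF7 cells (Homo sapiens) for cytotoxicity, read by MTT assay, with a stated time of 24 h (on this read-out lower numbers stand for stronger inhibition and higher numbers for weaker inhibition), compound 1 gives only a limit, > 850000 nM. For the measured compounds named here, compound 2 `COc1ccccc1N1CCN(CC(=O)N2CCN(c3nnc(-c4ccc(Cl)cc4)c(-c4ccc(Cl)cc4)n3)CC2)CC1`, which carries a methoxy on that phenyl, gives 330000 nM in this assay, the only actual number among the two measured compounds. Going by the values given here, the single measured step, an at least 2.5-fold lower number from compound 1 to compound 2 (0.41 log units; beyond the scatter), is an at-least figure because the limit of > 850000 nM in this assay, at which 1 of the 2 values shown sits, caps what compound 1 can show. Compound 3 `O=C(CN1CCN(c2ccccc2Cl)CC1)N1CCN(c2nnc(-c3ccc(Cl)cc3)c(-c3ccc(Cl)cc3)n2)CC1` differs from compound 2 by chloro in place of methoxy on an aromatic carbon. Among the compounds with values here, no measured step swaps one substituent for another on that phenyl, so the step from compound 1 to compound 2 bears on it only loosely: it shows that adding a methoxy changed the read-out in this assay. From the compounds shown here alone, since chloro against methoxy is untested, the expected step is a 1.1-fold lower number from compound 2 to compound 3 (0.04 log units; within the scatter), within the scatter. Compound 3 is therefore estimated at 300000 nM, between 100000 nM and 900000 nM in this assay.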

Compound 3, half-maximal inhibitory concentration: 396000 nM
The estimate for compound 3 lay 1.3-fold (0.12 log units) below the measured number; the measured number falls inside the stated range.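

In this assay chloro in place of methoxy gives a 1.2-fold higher number from compound 2 to compound 3 (0.08 log units; within the scatter) and so the 2-methoxyphenyl and 2-chlorophenyl groups cannot be told apart at this position. Chloro in place of hydrogen on the same carbon gives an at least 2.1-fold lower number from compound 1 to compound 3 (0.33 log units; beyond the scatter) and so methoxy is no longer the only group here that goes with a lower number than the unsubstituted phenyl. From the compounds shown here alone, the true size of that step stays unknown because compound 1 gives only a limit: the limit of > 850000 nM in this assay, at which 1 of the 3 values shown sits.

Going by these compounds, what an amine or a carboxylic acid would do on this carbon remains open, as does the effect of methoxy or chloro on another carbon of the ring. Two groups that read alike also cannot show which feature of a substituent goes with the lower number.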